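Swapping 4-methoxyphenyl for 3-chlorophenyl in a growth inhibitor

The source may report more compounds than this note shows. Statements on the series, on what has been measured and on what is new or still open speak of the compounds shown alone.

Measured in a functional assay on SiHa cells (Homo sapiens) for inhibition, read by sulforhodamine B assay; a higher number here means a weaker inhibitor of growth, a lower number a stronger inhibitor of growth:
- compound 1 `Oc1cccc2[nH]c(-c3ccc(-c4ccc(-c5ccccc5)cc4)cc3)nc12`: 9710 nM
- compound 2 `Oc1cccc2[nH]c(-c3ccc(-c4ccc(-c5ccc(C(F)(F)F)cc5)cc4)cc3)nc12`: 3720 nM
- compound 3 `COc1ccc(-c2ccc(-c3ccc(-c4nc5c(O)cccc5[nH]4)cc3)cc2)cc1`: 4800 nM

Compound 3 stands in the middle of this small range only loosely. Its number is lower than that of compound 1, a 2.0-fold lower number from compound 1 to compound 3 (0.31 log units; beyond the scatter), but it cannot be told apart from compound 2, a 1.3-fold higher number from compound 2 to compound 3 (0.11 log units; within the scatter).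

The next compound is compound 4 `Oc1cccc2[nH]c(-c3ccc(-c4ccc(-c5cccc(Cl)c5)cc4)cc3)nc12`, which carries 3-chlorophenyl in place of 4-methoxyphenyl on an aromatic carbon, para to a large group (3-chlorophenyl in place of 4-methoxyphenyl on an aromatic carbon).

For the measured compounds named here, no measured compound carries 3-chlorophenyl, so the evidence is indirect. Adding a group to compound 1 gave modest steps, a 2.6-fold lower number from compound 1 to compound 2 (0.42 log units; beyond the scatter) and the methoxy step above, while exchanging the two groups gave a step within the scatter. In this assay a change at this end of the molecule is therefore expected to be small, with no step beyond the scatter and no firm direction. The estimated step is a 1.0-fold higher number from compound 3 to compound 4 (0.02 log units; within the scatter). For compound 4 the expected value is 5000 nM, with an estimated range from 2500 nM to 10000 nM.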

Compound 4, concentration for 50% growth inhibition: 8400 nM
Compound 4: middle estimate off by 1.7-fold (0.23 log units), on the low side, and the stated range covers the measured number.
By their numbers in this assay, from the lowest: compounds 2, 3, 4 and 1 (each within the scatter of the next, the first and the last beyond it).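

In this assay, 3-chlorophenyl cannot be told apart from 4-methoxyphenyl at this position (a 1.8-fold higher number from compound 3 to compound 4 (0.24 log units; within the scatter)), and chloro in place of hydrogen leaves the number within the scatter of the parent (a 1.2-fold lower number from compound 1 to compound 4 (0.06 log units; within the scatter)). The exchange for 4-(trifluoromethyl)phenyl does clear the scatter (a 2.3-fold higher number from compound 2 to compound 4 (0.35 log units; beyond the scatter)), so substitution on this outer ring does not always produce a step beyond the scatter from compound 1, as it did for compound 2 and compound 3. No measurement given here explains these differences.

The compounds shown leave open whether the chloro itself or its place on the ring separates compound 4 from compound 2. They also leave open how an amine or a carboxylic acid on this ring would read in this assay.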